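A few compounds are considered here, and "the series" means these few. Any claim that something is new, unique, unknown or untested is made for them only; others in the source may bear on it.

Three compounds have been measured so far in a functional assay on B16-F0 cells (Mus musculus) for inhibition, read by CCK-8 assay, with a stated time of 48 h (on this read-out higher numbers stand for weaker inhibition and lower numbers for stronger inhibition), as follows:

- compound 1 `COc1cc(-c2ccnc3cc(-c4ccc(N(C)C)cc4)nn23)cc(OC)c1OC` gives 702 nM
- compound 2 `COc1cc(-c2ccnc3cc(-c4ccc5ccn(C)c5c4)nn23)cc(OC)c1OC` gives 657 nM
- compound 3 `COc1cc(-c2ccnc3cc(-c4ccc5cnn(C)c5c4)nn23)cc(OC)c1OC` gives 1000 nM

Compound 3 stands level with the other two, since both a 1.4-fold higher number from compound 1 to compound 3 (0.15 log units; within the scatter) and a 1.5-fold higher number from compound 2 to compound 3 (0.18 log units; within the scatter) lie within the scatter. The next compound, compound 4 `COc1cc(-c2ccnc3cc(-c4ccc(C(C)(C)C)cc4)nn23)cc(OC)c1OC`, carries 4-(tert-butyl)phenyl in place of 1-methyl-1H-indazol-6-yl on an aromatic carbon. The measured steps that bear on this change are the swaps at the same place, namely a 1.1-fold lower number from compound 1 to compound 2 (0.03 log units; within the scatter) along with the two above. All three are small and within the scatter. For the measured compounds named here, none of the measured compounds carries 4-(tert-butyl)phenyl, however, so these steps guide the expectation without settling it. No step beyond the scatter is therefore expected, and the estimated change is a 1.1-fold lower number from compound 3 to compound 4 (0.05 log units; within the scatter) in this read-out. The estimated value for compound 4 is 900 nM with an expected range of 350 nM to 2500 nM in this assay as the likely outcome.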

Compound 4, half-maximal inhibitory concentration: > 10000 nM
Compound 4: only a limit was reported (the forecaster's own chance of this, stated with the estimate: 5%); middle value at least 11-fold (1.04 log units) from the limit.
By their numbers in this assay, from the lowest: compounds 2, 1 and 3 (each within the scatter of the next). At a limit, above all of these: compound 4.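

Across the three earlier compounds, swaps at this position in this assay stayed within the scatter, but compound 4 departs from that picture and is reported only as a limit: the limit of > 10000 nM in this assay, at which 1 of the 4 values shown sits. The steps to it are an at least 10-fold higher number from compound 3 to compound 4 (1.00 log units; beyond the scatter), an at least 15-fold higher number from compound 2 to compound 4 (1.18 log units; beyond the scatter) and an at least 14-fold higher number from compound 1 to compound 4 (1.15 log units; beyond the scatter), so this position does not accept every aryl group alike. Compound 1 and compound 4 differ only in tert-butyl in place of dimethylamino, which shows that a change in that one group is enough, while 1-methyl-1H-indazol-6-yl and 4-(tert-butyl)phenyl share the same heavy-atom count.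

Going by these compounds, how far compound 4 lies past its limit remains unknown, so the full size of these steps stays open. Nor do the compounds shown tell whether a smaller methyl group or a morpholine in the place of tert-butyl would restore inhibition.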